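From methyl to an ester on compound 3

The source may hold more compounds than are shown below. What is called first, only, known or untested is meant among the compounds shown, and "the series" means these compounds.

In a functional assay on the whole organism with Rattus norvegicus as the target (a higher number here means that more compound is needed for the effect, a lower number that less compound is needed), compound 1 (`CC(C)(C)Cc1ccc2nc(N)sc2c1`) gives > 10 mg/kg as its result, which is a limit of the assay and not a number. Compound 2 (`Nc1nc2ccc(OC(F)(F)C(F)F)cc2s1`) needs 8.5 mg/kg for the half-maximal effect, and compound 3 (`Cn1c(=N)sc2cc(OC(F)(F)F)ccc21`) needs 5 mg/kg for it. These two numbers lie within the scatter of each other, so compound 3 stands level with compound 2 and neither can be ranked ahead.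

Compound 4 (`COC(=O)Cn1c(=N)sc2cc(OC(F)(F)F)ccc21`) differs from compound 3 by methoxycarbonyl in place of hydrogen on a saturated chain carbon bound to an aromatic nitrogen, which turns methyl into (methoxycarbonyl)methyl (methoxycarbonyl in place of hydrogen on a saturated chain carbon bound to an aromatic nitrogen). Going by the values given here, no measured pair shows a change of this kind, so the expectation is loose: a small move toward a higher number in this assay and probably none beyond the scatter. The estimated change is a 1.2-fold higher number from compound 3 to compound 4 (0.08 log units; within the scatter) on this reasoning. Compound 4 is expected at 6 mg/kg with an estimated range from 2 mg/kg to 18 mg/kg for its measurement.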

Compound 4, dose for half-maximal effect: > 10 mg/kg
Compound 4: no number, only a limit (the forecaster's own chance of this, stated with the estimate: 20%); middle value at least 1.6-fold (0.22 log units) from the limit.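

Going by these compounds alone, the change reads as an at least 2.0-fold higher number from compound 3 to compound 4 (0.30 log units; that floor lies within the scatter), the first step on record at the saturated chain carbon bound to an aromatic nitrogen. With that floor inside the scatter, the step does not by itself set compound 4 apart from compound 3, though it shows that methoxycarbonyl at this place brings no lower number in this assay. The value of compound 4, > 10 mg/kg, is a limit of the assay and not a number, so the full size of the step cannot be read: the limit of > 10 mg/kg in this assay, at which 2 of the 4 values shown sit.

The compounds shown carry only methyl and (methoxycarbonyl)methyl at this place, so they leave open whether the result goes with the ester or with the added length. A carboxylic acid, an amide or a plain longer chain at the same carbon would separate these readings.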